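Isomeric Ether Side Chains on a Shared Quinazoline-Free Core

A few compounds are considered here, and "the series" means these few. Any claim that something is new, unique, unknown or untested is made for them only; others in the source may bear on it.

Measured compounds:
Compound 1 `COc1cc2nc(N3CCC(OCCOc4ccccc4)CC3)nc(N)c2cc1OC` gives 0.48 nM in an assay on brain for displacement of a labelled ligand from Adrenergic receptor alpha-1 (Rattus norvegicus); a higher number here means a weaker inhibitor, a lower number a stronger inhibitor.
Compound 2 `COc1cc2nc(N3CCC(OCCO)CC3)nc(N)c2cc1OC` gives 2.2 nM in this assay.
Compound 3 `COc1cc2nc(N3CCC(OCC(C)(C)OC)CC3)nc(N)c2cc1OC` gives 1.14 nM in this assay.

Among the three numbers in this assay, compound 3 stands second highest; its nearest neighbour is compound 2, with a 1.9-fold lower number from compound 2 to compound 3 (0.29 log units; within the scatter), and its furthest is compound 1, with a 2.4-fold higher number from compound 1 to compound 3 (0.38 log units; beyond the scatter). Compound 4 `CCOC(C)COC1CCN(c2nc(N)c3cc(OC)c(OC)cc3n2)CC1` differs from compound 3 in one place: 1-ethoxyethyl in place of 1-methoxy-1-methylethyl on a saturated chain carbon bound to an oxygen on a saturated carbon.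

Going by the values given here, two measured steps touch this region of the molecule. The step of a 2.4-fold higher number from compound 1 to compound 3 (0.38 log units; beyond the scatter) replaces a phenoxymethyl with the 1-methoxy-1-methylethyl group, and the step of a 1.9-fold lower number from compound 2 to compound 3 (0.29 log units; within the scatter) replaces a hydroxymethyl with the same group. Among the compounds with values here, neither of them is a rearrangement of the same atoms, so no measured step reads directly on the change to compound 4. Since the two small ether and alcohol variants, compound 2 and compound 3, sit within the scatter of one another, compound 4 is expected to show no step beyond the scatter in this assay, that is a 1.1-fold higher number from compound 3 to compound 4 (0.02 log units; within the scatter). The estimate for compound 4 is 1.2 nM, with a range from 0.5 nM to 3 nM.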

Compound 4, inhibition constant: 0.99 nM
Estimate against measurement, compound 4: 1.2-fold (0.08 log units) above; low and high end bracket the measured number.
By their numbers in this assay, from the lowest: compound 1; then compounds 4, 3 and 2 (each within the scatter of the next, the first and the last beyond it).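

Joining the same atoms differently, as 1-ethoxyethyl in place of 1-methoxy-1-methylethyl, gives a pair that stands within the scatter in this assay (a 1.2-fold lower number from compound 3 to compound 4 (0.06 log units; within the scatter)), and this is the first pair at this position to hold the atom count fixed. Compound 4 stands apart, modestly, from both the hydroxymethyl and the phenoxymethyl compounds (a 2.2-fold lower number from compound 2 to compound 4 (0.35 log units; beyond the scatter); a 2.1-fold higher number from compound 1 to compound 4 (0.31 log units; beyond the scatter)), but no pattern for the ethers follows, since compound 3 goes against it by staying within the scatter of compound 2. No supporting data bear on why these numbers fall as they do.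

The compounds shown leave open how an amine or a carboxylic acid on this saturated chain carbon would read in this assay. They also leave open whether a longer chain, or a benzyl ether in place of the phenoxymethyl, would keep a number as low as that of compound 1.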